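A few compounds are considered here, and "the series" means these few. Any claim that something is new, unique, unknown or untested is made for them only; others in the source may bear on it.

Of the compounds shown here, two of a shared core have been measured in a functional assay on a cell-free system (plasma, Homo sapiens), with a stated time of 3 min; on this read-out higher numbers stand for weaker inhibition and lower numbers for stronger inhibition. Compound 1, `CC(C)(C)[C@@H](O)C(=O)N1[C@@H]2C[C@@H]2C[C@H]1C(=O)NCc1cc(Cl)ccc1-n1cnnn1`, gives 1100 nM in this assay. Compound 2, `CCCC[C@@H](O)C(=O)N1N=CC[C@H]1C(=O)NCc1cc(Cl)ccc1-n1cnnn1`, gives 610 nM in this assay. Of these two numbers compound 1 has the higher one, but the two values lie within the scatter of each other, so nothing can be said about which of the two inhibits more strongly.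

The next compound, compound 3, `O=C(NCc1cc(Cl)ccc1-n1cnnn1)[C@@H]1C[C@H]2C[C@H]2N1C(=O)[C@H](O)CC1CC1`, keeps the core of compound 1 and changes one group: cyclopropylmethyl in place of tert-butyl on a saturated chain carbon bound to a carbonyl carbon and an oxygen on a saturated carbon. The group that leaves and the group that enters are each built from four carbon atoms, carry no hydrogen-bond donors or acceptors and no charge, and differ only in that the one entering contains a three-membered ring of carbon. Among the compounds with values here, no measured pair shows the effect of such a change here, so the expectation rests on size alone.

In this assay compound 3 is expected to give 900 nM, with a likely range from 400 nM to 2000 nM. The step expected from compound 1 to compound 3, a 1.2-fold lower number from compound 1 to compound 3 (0.09 log units; within the scatter), is estimated to stay within the scatter, in no clear direction.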

Compound 3, half-maximal inhibitory concentration: 850 nM
Beside the measured number, compound 3's estimate is 1.1-fold (0.02 log units) above it, and the stated range covers the measured number.
By their numbers in this assay, from the lowest: compounds 2, 3 and 1 (each within the scatter of the next).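

In this assay, within the data shown here, cyclopropylmethyl in place of tert-butyl on a saturated chain carbon bound to a carbonyl carbon and an oxygen on a saturated carbon gives a 1.3-fold lower number from compound 1 to compound 3 (0.11 log units; within the scatter), and this is the first pair in which only this group differs. At this place and on the core of compound 1, the read-out therefore does not separate these two groups, each built from four carbon atoms, even though only cyclopropylmethyl contains a three-membered ring of carbon. No measurement shown here offers an explanation for this result.

Among these compounds, compound 2 differs from compound 1 and compound 3 in more than one place, so no step involving it can be read, and its separate contribution from the group at this place and from the core stays unknown. It also remains open whether a group that is not made of carbon alone, such as an amine or a carboxylic acid, would at this same place give a number beyond the scatter of this assay, since the single step shown compares only two all-carbon groups.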